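The source may report more compounds than this note shows. Statements on the series, on what has been measured and on what is new or still open speak of the compounds shown alone.

Measured compounds:
- compound 1 `O=S(=O)(Nc1ccc(-c2nc3ccccc3o2)cc1)c1cccc(F)c1`: 71000 nM
- compound 2 `Cc1ccc(S(=O)(=O)Nc2ccc3oc(-c4ccccc4)nc3c2)cc1`: > 100000 nM
- compound 3 `O=S(=O)(Nc1ccc2oc(-c3ccccc3)nc2c1)c1ccccc1Cl`: > 100000 nM

Going by the values given here, in an assay on cells for inhibition of HSP60/HSP10 (Homo sapiens), with a stated time of 60 min (on this read-out higher numbers stand for weaker inhibition and lower numbers for stronger inhibition), compound 1 gives 71000 nM, and this is the only number in the set. Compound 2 reaches only the limit of > 100000 nM in this assay. Compound 3 likewise sits at the limit of > 100000 nM in this assay. Both of these are limits of the assay, not numbers, as the limit of > 100000 nM in this assay, at which 2 of the 3 values shown sit, records. Among the compounds with values here, the one step between measured compounds, a step that the two limits leave unreadable from compound 2 to compound 3, is therefore unreadable in size.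

Compound 4 `C=Cc1ccc(S(=O)(=O)Nc2ccc(-c3nc4ccccc4o3)cc2)cc1` is not yet measured. It differs from compound 1 in one place: 4-vinylphenyl in place of 3-fluorophenyl on a sulfonyl sulfur. Within the data shown here, no measured step touches the same change, since the step from compound 2 to compound 3 is hidden by two limits, and compound 1 itself stands at a weak value. With nothing readable to lean on, compound 4 is expected to stay close to compound 1, a step of a 1.1-fold higher number from compound 1 to compound 4 (0.02 log units; within the scatter) that lies within the scatter. Compound 4 is therefore estimated at 75000 nM in this assay, with a range from 30000 nM to 200000 nM, and a real chance that this assay reports only a limit for compound 4.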

Compound 4, half-maximal inhibitory concentration: > 100000 nM
Compound 4: a limit, no number (the forecaster's own chance of this, stated with the estimate: 40%); at least 1.3-fold (0.12 log units) between middle value and limit.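

Going by these compounds alone, the change to 4-vinylphenyl in place of 3-fluorophenyl on a sulfonyl sulfur gives the first step at this position with a readable floor: an at least 1.4-fold higher number from compound 1 to compound 4 (0.14 log units; that floor lies within the scatter). On these data alone, that floor does not show a loss beyond the scatter, and the true size of the step stays unknown, since one end of it is a limit of the assay and not a number. Replacing the 3-fluorophenyl of compound 1 with a 4-vinylphenyl also did not bring the series into the measured range, and most of the set now stands at the same limit: the limit of > 100000 nM in this assay, at which 3 of the 4 values shown sit.

The compounds shown leave open whether any group on this sulfonyl sulfur can give a clearly lower number in this assay than compound 1 does with 71000 nM. They also say nothing about how a phenyl ring carrying an amine or a carboxylic acid would read at this place, or how a longer chain in place of the vinyl group would read.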